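A few compounds are considered here, and "the series" means these few. Any claim that something is new, unique, unknown or untested is made for them only; others in the source may bear on it.

Measured so far in an ADME assay on FM3A cells (Mus musculus); on this read-out lower numbers stand for an effect already at smaller amounts and higher numbers for an effect only at larger amounts of compound:
- compound 1 `COC12CCC[C@@H](C1)C(C)(CI)OO2`: > 70000 nM
- compound 2 `COC12C[C@H](CC[C@@H]1C)C(C)(CI)OO2`: > 54000 nM

Compound 1 stands only at a limit, > 70000 nM, so no number is available as a starting point. Compound 2 also gives only a limit, > 54000 nM.

The next compound is compound 3 `CC12CCC[C@@H](C1)C(C)(CI)OO2`, which differs from compound 1 by one exchange: methyl in place of methoxy on a saturated ring carbon. In words, this is methyl in place of methoxy on a saturated ring carbon, while the rest of the core of compound 1 is unchanged.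

Among the measured compounds shown here, only one measured step bears on this, and only loosely: a step that the two limits leave unreadable from compound 1 to compound 2. That step is methyl in place of hydrogen on a saturated ring carbon, a different exchange at a different place, and it has no readable size or direction. No step beyond the scatter is therefore expected in this assay, and the expected step is an at least 1.1-fold lower number from compound 1 to compound 3 (0.06 log units; that floor lies within the scatter). A report of only a limit is also considered likely for compound 3.

For compound 3 the estimated value is 60000 nM, with an expected range from 20000 nM to 120000 nM.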

Compound 3, half-maximal effective concentration: > 84000 nM
Compound 3: no number, only a limit; the forecaster's own chance of this, stated with the estimate: 65%; middle value at least 1.4-fold (0.14 log units) from the limit.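

Among the compounds shown here, compound 1 and compound 3 both stand only at limits, and no step between them can be read. The compounds shown leave open where the actual half-maximal concentrations lie and whether methyl in place of methoxy on a saturated ring carbon shifts the result at all in this assay.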